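The source may report more compounds than this note shows. Statements on the series, on what has been measured and on what is new or still open speak of the compounds shown alone.

Of the compounds shown here, two have numbers so far in a functional assay on Jurkat cells (Homo sapiens) for cytotoxicity, read by MTT assay, with a stated time of 72 h; on this read-out higher numbers stand for weaker inhibition and lower numbers for stronger inhibition. Compound 1 (`COc1ccc(NC(=O)Nc2ccc(/C=C/C(=O)NO)cc2)cc1`) gives 110 nM and compound 2 (`O=C(CCc1ccc(NC(=O)Nc2ccc(Cl)cc2)cc1)NO`) gives 410 nM. Compound 2 thus holds the higher of the two numbers, meaning the weaker inhibition, and its gap to compound 1 lies beyond the scatter. These two compounds differ in more than one place, so no single-change step can be read from them.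

Compound 3 (`COc1ccc(NC(=O)Nc2ccc(CCC(=O)NO)cc2)cc1`) comes from compound 2 by one change: methoxy in place of chloro on an aromatic carbon, para to a large group. Within the data shown here, no measured pair shows this exchange, so its size has no direct precedent. The expectation therefore stays anchored on compound 2 at 410 nM, with no step beyond the scatter expected in this assay. The estimated change is a 1.2-fold lower number from compound 2 to compound 3 (0.07 log units; within the scatter). For compound 3 the estimated value is 350 nM, with an expected range from 140 nM to 850 nM.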

Compound 3, half-maximal inhibitory concentration: 2800 nM
Compound 3: the middle estimate sits 8.0-fold (0.90 log units) below what was measured, and the stated range ends below it.
By their numbers in this assay, from the lowest: compound 1; then compound 2; then compound 3.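

In this assay, the exchange of chloro for methoxy, para to a large group, is not neutral: the series gives a 6.8-fold higher number from compound 2 to compound 3 (0.83 log units; beyond the scatter), so this place on the aromatic ring responds to the group it carries, which the earlier pair, differing in more than one place, could not show. With methoxy held fixed, the chain also counts: 2-(hydroxycarbamoyl)ethyl in place of 2-(hydroxycarbamoyl)ethenyl gives a 25-fold higher number from compound 1 to compound 3 (1.41 log units; beyond the scatter), so the methoxy compounds separate on the chain alone. No measurement at hand bears on what lies behind either step.

As far as these compounds go, each step rests on a single pair, so it remains open whether the preference for chloro over methoxy carries over to the 2-(hydroxycarbamoyl)ethenyl chain, and whether the cost of the 2-(hydroxycarbamoyl)ethyl chain is the same with chloro on the ring. Also open, from the compounds shown here alone, is how a fluoro, methyl or dimethylamino group would fall at this place, and whether the ranking of chloro above methoxy extends to any group beyond these two.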